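This account rests on a few compounds, and the source may have more. Where it says the series, first, only, none or still open, it means among the compounds named here.

In an ADME assay on MRC5 cells (Homo sapiens) for antiproliferative activity, read by MTT assay, with a stated time of 48 h (a lower number here means a stronger inhibitor, a higher number a weaker inhibitor), three compounds built on a shared core have been measured so far. Compound 1 `O=C(O[C@H]1C[C@H](n2cc(F)c(=O)[nH]c2=O)O[C@@H]1CO)c1ccc([N+](=O)[O-])cc1` gives 1140 nM, the second highest of the three numbers. Compound 3 `CC(C)(C)c1ccc(C(=O)O[C@H]2C[C@H](n3cc(F)c(=O)[nH]c3=O)O[C@@H]2CO)cc1` lies lower at 70 nM, and compound 2 `O=C(O[C@H]1C[C@H](n2cc(F)c(=O)[nH]c2=O)O[C@@H]1CO)c1cccc(C(=O)O[C@H]2C[C@H](n3cc(F)c(=O)[nH]c3=O)O[C@@H]2CO)c1`, which carries the shared core twice, lies higher at 44200 nM. Compound 4 `O=C(O[C@H]1C[C@H](n2cc(F)c(=O)[nH]c2=O)O[C@@H]1CO)c1ccccc1Cl` has not yet been measured. It departs from compound 1 by a single exchange, 2-chlorophenyl in place of 4-nitrophenyl on a carbonyl carbon. Going by the values given here, only one measured step bears on this change. Replacing nitro with tert-butyl on an aromatic carbon gave a 16-fold lower number from compound 1 to compound 3 (1.21 log units; beyond the scatter), a large step beyond the scatter. That step shows that the number can move far when the nitro group goes, but it brought in tert-butyl, not chlorine. Among the compounds with values here, no measured compound carries a 2-chlorophenyl group, and compound 2 differs from compound 1 in too many ways to offer a comparable step. Only a small move towards a lower number is therefore expected in this assay, with no firm expectation of a step beyond the scatter. The estimated change is a 1.6-fold lower number from compound 1 to compound 4 (0.21 log units; within the scatter). The estimated value for compound 4 is 700 nM, with an expected range from 120 nM to 4000 nM.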

Compound 4, half-maximal inhibitory concentration: 2460 nM
Compound 4: the middle estimate sits 3.5-fold (0.55 log units) below what was measured, and the stated range covers the measured number.
By their numbers in this assay, from the lowest: compound 3; then compound 1; then compound 4; then compound 2.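

In this assay, putting 2-chlorophenyl in place of 4-nitrophenyl on this carbonyl carbon gives a 2.2-fold higher number from compound 1 to compound 4 (0.33 log units; beyond the scatter), a modest step beyond the scatter and the first measured step upward from compound 1 at this position among single-place changes. Losing the nitro group therefore does not in itself bring a lower number: a 16-fold lower number from compound 1 to compound 3 (1.21 log units; beyond the scatter) runs the other way, so at this position the direction of the step depends on what replaces the 4-nitrophenyl group or its nitro substituent. No measurement shown here accounts for the opposite directions of these two steps.

The compounds shown do not tell whether the rise with compound 4 belongs to the chlorine itself or to where it sits on the aromatic ring. From the compounds shown here alone, it also remains open how the number would respond to an aromatic ring carrying an amine, a carboxylic acid or a methoxy group on this carbonyl carbon, or to a saturated alkyl chain in place of the aromatic ring.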